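Replacing a Sulfonyl Piperidine with a Methylpiperazine Propyl Chain

The source may hold more compounds than are shown below. What is called first, only, known or untested is meant among the compounds shown, and "the series" means these compounds.

Measured compounds:
compound 1 `Cc1ccccc1-c1nn(-c2ccc(F)cc2F)cc1CNC1CCN(S(C)(=O)=O)CC1` gives > 20000 nM
compound 2 `Cc1ccccc1-c1nn(-c2ccc(Cl)cc2)cc1CNCCN1CCN(C)CC1` gives 17000 nM
compound 3 `CCCN1CCC(CNCc2cn(-c3ccc(C(F)(F)F)cc3)nc2-c2ccc(C(F)(F)F)cc2)CC1` gives 1200 nM

All three were tested in an ADME assay on Huh-7 cells (Homo sapiens) for cytotoxicity; a lower number here means that less compound is tolerated, a higher number that more compound is tolerated. The reading for compound 1 is only a limit of the assay, so its tolerated concentration is not pinned to a number. Among the three readings, compound 1 sits at the top edge of what the assay reports (the limit of > 20000 nM in this assay, at which 1 of the 3 values shown sits). Compound 2 and compound 3 give plain numbers, and compound 3 tolerates the least compound of the set. No two of these compounds differ in a single place, so none of the gaps between them can be read as a clean step.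

Compound 4 `Cc1ccccc1-c1nn(-c2ccc(F)cc2F)cc1CNCCCN1CCN(C)CC1` is the next compound to be tested in this assay. It differs from compound 1 in one place: 3-(4-methylpiperazin-1-yl)propyl in place of 1-(methylsulfonyl)piperidin-4-yl on an amine nitrogen

For the measured compounds named here, no measured step guides this change directly. Compound 2 carries a related methylpiperazine chain on its amine and gives 17000 nM, which offers the closest point of comparison. Compound 4 is therefore expected to come out a little lower than the limit of compound 1, and the step of an at least 1.6-fold lower number from compound 1 to compound 4 (0.22 log units; that floor lies within the scatter) is expected to be modest. Compound 4 is estimated at 12000 nM, within a range from 4000 nM to 40000 nM.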

Compound 4, half-maximal cytotoxic concentration: > 20000 nM
Compound 4 gave a limit, no number; the forecaster's own chance of this, stated with the estimate: 35%; middle value at least 1.6-fold (0.22 log units) away from the limit.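

In this assay compound 4 gives > 20000 nM, which is a limit and not a number. For the compounds shown here, compound 1 also gives only a limit, so no step from compound 1 to compound 4 can be read: the limit of > 20000 nM in this assay, at which 2 of the 4 values shown sit. As far as these compounds go, whether 3-(4-methylpiperazin-1-yl)propyl in place of 1-(methylsulfonyl)piperidin-4-yl changes the tolerated concentration at all stays open.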